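This account rests on a few compounds, and the source may have more. Where it says the series, first, only, none or still open, it means among the compounds named here.

Measured so far:
compound 1, `COCc1ccccc1C1CCc2nc[nH]c2C1` — 87%; 83% (2 entries)
compound 2, `COc1ccc(C2Cc3nccn3C2)cc1` — 27%

In a functional assay on CHO cells for agonist activity at Alpha-1A adrenergic receptor (Homo sapiens), read by FLIPR and calcium flux (on this read-out lower numbers stand for smaller maximal responses and higher numbers for larger maximal responses), compound 1 gives 87%; 83% (2 entries); its repeat entries, (the several entries of compound 1 in this assay, 87%; 83% (2 entries)), agree within the usual scatter. Compound 2 gives 27% in this assay, the only number shown for it, well below the values of compound 1. Compound 3, `Clc1ccc(C2Cc3nccn3C2)cc1`, is not yet measured. It differs from compound 2 by chloro in place of methoxy on an aromatic carbon, on an aromatic carbon of a six-membered aromatic ring of carbon only. Among the measured compounds shown here, no measured pair shows this change, so in this assay a step within the scatter is expected, with no direction assumed. Compound 3 is expected at 30%, range 10% to 60%. The step implied is expected to be a number 3 percentage points higher from compound 2 to compound 3 (within the scatter).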

Compound 3, largest response reached (Emax), in percent of the reference or control that the assay uses in the Alpha-1A adrenergic receptor assay: 45%
Beside the measured number, compound 3's estimate is 15 percentage points below it, within the range that was stated.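

On the aromatic carbon para to a group of 8 heavy atoms, the series now has its first readable step: in the Alpha-1A adrenergic receptor assay, chloro in place of methoxy raises the maximal response (a number 18 percentage points higher from compound 2 to compound 3 (beyond the scatter)). In a physicochemical assay for lipophilicity, at pH 7.4 (on this read-out higher numbers stand for higher lipophilicity and lower numbers for lower lipophilicity), compound 2 gives 2 and compound 3 gives 2.6 so the same change moves both read-outs.

A single pair cannot show whether the two read-outs move together. As far as these compounds go, how an amine, a carboxylic acid or a longer chain at this place would read in the Alpha-1A adrenergic receptor assay remains open.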